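Sulfonamide aryl exchange and cytotoxicity: compound 3 to compound 4

The source may report more compounds than this note shows. Statements on the series, on what has been measured and on what is new or still open speak of the compounds shown alone.

Compound 1 `C=Cc1ccc(S(=O)(=O)Nc2ccc3oc(-c4ccccc4)nc3c2)cc1` and compound 2 `O=S(=O)(Nc1ccc2oc(-c3ccccc3)nc2c1)c1cccc(F)c1` share a core and differ only in the aryl group on the sulfonyl sulfur. In an ADME assay on HEK293 cells (Homo sapiens) for cytotoxicity, read by resazurin assay, with a stated time of 48 h (on this read-out higher numbers stand for lower toxicity in this test and lower numbers for higher toxicity in this test), compound 1 gives 53000 nM. In this assay compound 2 gives 68000 nM. The step of a 1.3-fold higher number from compound 1 to compound 2 (0.11 log units; within the scatter) thus shows no change beyond the scatter for an aryl exchange at this position.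

Compound 3 `O=S(=O)(Nc1ccc(-c2nc3ccccc3o2)cc1)c1cccs1` carries a different arrangement of the shared core. In this assay compound 3 reaches only a limit of the assay, > 100000 nM. Compound 3 sits at the limit of > 100000 nM in this assay, at which 1 of the 3 values shown sits.

Compound 4 `O=S(=O)(Nc1ccc(-c2nc3ccccc3o2)cc1)c1ccc(Cl)c(Cl)c1` differs from compound 3 in one place: 3,4-dichlorophenyl in place of thiophen-2-yl on a sulfonyl sulfur. For the measured compounds named here, the only measured step that bears on this change, an aryl exchange on the sulfonyl sulfur, is a 1.3-fold higher number from compound 1 to compound 2 (0.11 log units; within the scatter), which stayed within the scatter; it involved neither thiophen-2-yl nor 3,4-dichlorophenyl and sits on another arrangement of the core, so its guidance is weak. On the shown numbers no step beyond the scatter is expected in this assay from this change, and a limit remains likely.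

For compound 4 the expected value is 80000 nM, with a range from 30000 nM to 200000 nM. The step this estimate implies is an at least 1.2-fold lower number from compound 3 to compound 4 (0.09 log units; that floor lies within the scatter), an expectation only, as the starting point is a limit.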

Compound 4, half-maximal cytotoxic concentration: > 100000 nM
Compound 4 ended at the assay's limit; the forecaster's own chance of this, stated with the estimate: 45%; at least 1.2-fold (0.09 log units) between middle value and limit.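

In this assay no step can be read from compound 3 to compound 4, as both stand at a limit of the assay: the limit of > 100000 nM in this assay, at which 2 of the 4 values shown sit.

The compounds shown leave open whether 3,4-dichlorophenyl in place of thiophen-2-yl on a sulfonyl sulfur changes this read-out at all, and how far past the limit either compound lies.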